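The compounds below may be only part of what the source reports. "The series", "measured", "known", "first", "only" and "open" are said of these compounds alone.

Compound 1 `COc1cc2ncnc(Nc3ccc(F)c(Cl)c3)c2cc1OCCCSc1nc2ccccc2s1` and compound 2 `COc1ccc(Nc2ncnc3cc(OC)c(OCCCSc4nc5ccccc5s4)cc23)cc1` share the same core and differ only in the aryl group on a nitrogen on an aromatic ring. In a functional assay on MCF7 cells (Homo sapiens) for cytotoxicity, read by MTT assay, with a stated time of 24 h (a higher number here means a weaker inhibitor, a lower number a stronger inhibitor), compound 1 gives 5370 nM, and compound 2 gives 14200 nM; the step of a 2.6-fold higher number from compound 1 to compound 2 (0.42 log units; beyond the scatter) lies beyond the scatter, so compound 1 stands as the lower of the two numbers shown. Compound 3 `COc1cc2ncnc(Nc3ccc(F)c(Cl)c3)c2cc1OCCCSc1nc2ccccc2o1` has not yet been measured. It differs from compound 1 by 1,3-benzoxazol-2-yl in place of 1,3-benzothiazol-2-yl on a sulfur. For the measured compounds named here, the single measured step, a 2.6-fold higher number from compound 1 to compound 2 (0.42 log units; beyond the scatter), concerns the group on a nitrogen on an aromatic ring and leaves the group on the sulfur untouched, so nothing measured here speaks directly to this exchange. The step expected in this assay is therefore a 1.1-fold higher number from compound 1 to compound 3 (0.05 log units; within the scatter), no change beyond the scatter. On that basis compound 3 is estimated at 6000 nM, with a range from 2500 nM to 15000 nM.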

Compound 3, half-maximal inhibitory concentration: 4050 nM
Estimate against measurement, compound 3: 1.5-fold (0.17 log units) above; low and high end bracket the measured number.
By their numbers in this assay, from the lowest: compounds 3 and 1 (each within the scatter of the next); then compound 2.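

In this assay, replacing 1,3-benzothiazol-2-yl with 1,3-benzoxazol-2-yl on the sulfur gives a step within the scatter (a 1.3-fold lower number from compound 1 to compound 3 (0.12 log units; within the scatter)), so this assay does not separate the two groups at this position. This is the only step shown at the sulfur, and it differs from the step at the aryl group on the nitrogen (a 2.6-fold higher number from compound 1 to compound 2 (0.42 log units; beyond the scatter)), which lies beyond the scatter. No measurement of any other kind is available to account for either result.

As far as these compounds go, it remains open whether a phenyl or pyridin-2-yl group on the sulfur would also read alike, and whether a longer chain to the sulfur would alter the number. Also open, from the compounds shown here alone, is whether 1,3-benzoxazol-2-yl would behave the same way alongside the 4-methoxyphenyl group of compound 2.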